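The source may hold more compounds than are shown below. What is called first, only, known or untested is meant among the compounds shown, and "the series" means these compounds.

Compound 1, `Cc1nc(N)sc1CCCN/C(N)=N/C(=O)NC(C)c1ccc(Br)cc1`, gives 0.87 in a functional assay on Right cardiac atrium for agonist activity at histamine H2 receptor (Cavia porcellus), with a stated time of 30 min, in the presence of a further agent that is not named here; on this read-out lower numbers stand for smaller maximal responses and higher numbers for larger maximal responses.
Compound 2, `Cc1nc(N)sc1CCCN/C(N)=N/C(=O)NC(c1ccccc1)C(C)C`, gives 1.04 in this assay.
Compound 3, `Cc1nc(N)sc1CCCN/C(N)=N/C(=O)NC(C)c1ccc(Cl)cc1`, gives 0.93 in this assay.

Among these three numbers compound 3 sits second highest. Its nearest neighbour is compound 1: the step a number 0.060 higher from compound 1 to compound 3 (within the scatter) lies within the usual scatter of this kind of measurement, so the two cannot be told apart. Compound 2 stands higher than compound 3 by an amount beyond the scatter, and no single-point comparison between those two is available.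

Compound 4, `Cc1nc(N)sc1CCCN/C(N)=N/C(=O)NC(C)c1ccc(F)cc1`, has not yet been measured. It differs from compound 3 in one place: fluoro in place of chloro on an aromatic carbon. Going by the values given here, the one measured step that bears on this is the halogen swap a number 0.060 higher from compound 1 to compound 3 (within the scatter), which stayed within the scatter. Exchanging one halogen for another at this position has therefore, so far, left the maximal response essentially unchanged. For compound 4 the expectation is a step of a number 0.020 higher from compound 3 to compound 4 (within the scatter), that is, no change beyond the scatter, and its value in this assay is estimated at 0.95, with a range from 0.84 to 1.06.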

Compound 4, intrinsic activity: the largest response reached, as a fraction of the reference agonist's: 0.92
Beside the measured number, compound 4's estimate is 0.030 above it; low and high end bracket the measured number.
By their numbers in this assay, from the lowest: compounds 1, 4 and 3 (each within the scatter of the next); then compound 2.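

In this assay, the step a number 0.010 lower from compound 3 to compound 4 (within the scatter) and the step a number 0.050 higher from compound 1 to compound 4 (within the scatter) both stay within the scatter, so fluoro now joins chloro and bromo as a group that cannot be told apart from the others at this place. Before, only the bromo and chloro pair could be compared; now all three pairs among compound 1, compound 3 and compound 4 can be, and none shows a readable change in maximal response. No measurement shown here offers an explanation for this sameness.

From the compounds shown here alone, it remains open whether the same holds for a group other than a halogen at this place, such as an amine, a carboxylic acid or a longer alkyl chain. Compound 2 differs from the halogen compounds in more than one place, so its value of 1.04 cannot be tied to any single change.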